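The source may report more compounds than this note shows. Statements on the series, on what has been measured and on what is new or still open speak of the compounds shown alone.

In a functional assay on CNE-2 cells (Homo sapiens) for antiproliferative activity, read by sulforhodamine B assay, with a stated time of 48 h (a higher number here means a weaker inhibitor, a lower number a stronger inhibitor), compound 1 `COc1cccc(/C=C/C(=O)C(=Cc2ccc(F)cc2)C(=O)/C=C/c2cccc(OC)c2OC)c1OC` gives 610 nM, compound 2 `COc1ccc(C=C(C(=O)/C=C/c2cccc(OC)c2OC)C(=O)/C=C/c2cccc(OC)c2OC)cc1OC` gives 280 nM, and compound 3 `COc1cccc(/C=C/C(=O)C(=Cc2cc(OC)c(OC)c(OC)c2)C(=O)/C=C/c2cccc(OC)c2OC)c1OC` gives 400 nM. Compound 1 therefore has the highest number of the three, but only one of its gaps is clearly real. The step of a 2.2-fold lower number from compound 1 to compound 2 (0.34 log units; beyond the scatter) clears the scatter, whereas the step of a 1.5-fold lower number from compound 1 to compound 3 (0.18 log units; within the scatter) does not, and neither does the step of a 1.4-fold higher number from compound 2 to compound 3 (0.15 log units; within the scatter).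

Compound 4 `COc1cc(C=C(C(=O)/C=C/c2cccc(OC)c2OC)C(=O)/C=C/c2cccc(OC)c2OC)cc(Br)c1O` keeps the core of compound 1 and changes one group: 3-bromo-4-hydroxy-5-methoxyphenyl in place of 4-fluorophenyl on a double-bonded chain carbon bound to a double-bonded chain carbon. The two steps from compound 1 bear on this most directly, since each replaces the same 4-fluorophenyl with a methoxy-bearing phenyl group. Both point towards a lower number, though they are small. Within the data shown here, no measured compound carries a bromine or a hydroxy group, so the data cannot show what those two additions do.

A small step towards a lower number is therefore expected in this assay, estimated as a 1.7-fold lower number from compound 1 to compound 4 (0.24 log units; within the scatter). Compound 4 is estimated at 350 nM, with an expected range of 130 nM to 900 nM.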

Compound 4, half-maximal inhibitory concentration: 220 nM
The estimate for compound 4 lay 1.6-fold (0.20 log units) above the measured number; low and high end bracket the measured number.
By their numbers in this assay, from the lowest: compounds 4, 2, 3 and 1 (each within the scatter of the next, the first and the last beyond it).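

At this place on a double-bonded chain carbon, a phenyl group carrying bromine and hydroxy does not cost activity in this assay: replacing 4-fluorophenyl with 3-bromo-4-hydroxy-5-methoxyphenyl gives a 2.8-fold lower number from compound 1 to compound 4 (0.44 log units; beyond the scatter) and so clears the scatter, as 3,4-dimethoxyphenyl had done. Against the groups with methoxy alone, the new group cannot be told apart: a 1.8-fold lower number from compound 3 to compound 4 (0.26 log units; within the scatter) and a 1.3-fold lower number from compound 2 to compound 4 (0.10 log units; within the scatter) both stay within the scatter, so these three replacements show no clear order among themselves. Nothing available explains the gain over 4-fluorophenyl.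

The compounds shown leave open what the bromine and the hydroxy each do alone on this phenyl group. They also leave open how this place would respond to an amine, a carboxylic acid or a longer chain in place of the phenyl group.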